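Methyl in Place of Methoxy on the Shared Core

The source may report more compounds than this note shows. Statements on the series, on what has been measured and on what is new or still open speak of the compounds shown alone.

Three compounds share a core that differs only at one aromatic carbon. Compound 1 `O=C(Nc1nc2ccc(F)cc2s1)c1cn(-c2ccccc2)nc1-c1ccccc1` carries a fluoro group there, and in an ADME assay on HEK-293T cells (Homo sapiens) for cytotoxicity, read by MTT assay, with a stated time of 72 h (a lower number here means a stronger inhibitor, a higher number a weaker inhibitor), compound 1 gives 17600 nM. Compound 2 `O=C(Nc1nc2ccc(Cl)cc2s1)c1cn(-c2ccccc2)nc1-c1ccccc1` carries a chloro group, and in this assay compound 2 gives 21300 nM; the step of a 1.2-fold higher number from compound 1 to compound 2 (0.08 log units; within the scatter). Compound 3 `COc1ccc2nc(NC(=O)c3cn(-c4ccccc4)nc3-c3ccccc3)sc2c1` carries a methoxy group. In this assay compound 3 gives > 50000 nM, which is a limit of the assay and not a number; it sits at the limit of > 50000 nM in this assay, at which 1 of the 3 values shown sits. The steps of an at least 2.8-fold higher number from compound 1 to compound 3 (0.45 log units; beyond the scatter) and an at least 2.3-fold higher number from compound 2 to compound 3 (0.37 log units; beyond the scatter) both point the same way.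

Compound 4 `Cc1ccc2nc(NC(=O)c3cn(-c4ccccc4)nc3-c3ccccc3)sc2c1` is not yet measured. The change from compound 3 is methyl in place of methoxy on an aromatic carbon. Since the halogen compounds 1 and 2 gave numbers and the methoxy compound 3 only a limit, a methyl group is expected to land between them or near the limit. Compound 4 is expected to give 35000 nM, with a range from 15000 nM to 80000 nM. This estimate implies an expected step of an at least 1.4-fold lower number from compound 3 to compound 4 (0.15 log units; that floor lies within the scatter).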

Compound 4, half-maximal inhibitory concentration: > 50000 nM
Compound 4 was reported as a limit (the forecaster's own chance of this, stated with the estimate: 40%); middle value at least 1.4-fold (0.15 log units) from the limit.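

Methyl in place of chloro gives an at least 2.3-fold higher number from compound 2 to compound 4 (0.37 log units; beyond the scatter), and methyl in place of fluoro gives an at least 2.8-fold higher number from compound 1 to compound 4 (0.45 log units; beyond the scatter), so at this aromatic carbon the move away from the halogen compounds is no longer seen with methoxy alone but also with a group that holds no oxygen. Among the four compounds, only the fluoro and chloro groups give a number in this assay, while compound 4 joins compound 3 at a limit of the assay: the limit of > 50000 nM in this assay, at which 2 of the 4 values shown sit. The two limits leave the step between compound 3 and compound 4 unreadable, so methyl and methoxy cannot be ranked against each other.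

Going by these compounds, how far compound 3 and compound 4 lie past that limit stays open. So does whether an amine, a carboxylic acid or a longer chain at this aromatic carbon would give a number or another limit.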